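A few compounds are considered here, and "the series" means these few. Any claim that something is new, unique, unknown or untested is made for them only; others in the source may bear on it.

For the measured compounds named here, in an ADME assay on J774.A1 cells (Mus musculus) for inhibition, read by MTT assay, with a stated time of 72 h (on this read-out lower numbers stand for an effect already at smaller amounts and higher numbers for an effect only at larger amounts of compound), three compounds with a shared core have numbers so far. Compound 1 `CC(C)Nc1nc(NCc2ccco2)c2ccccc2n1` sits at 17000 nM and compound 2 `Clc1ccc(CNc2nc(NCc3ccccc3)nc3ccccc23)cc1` at 4600 nM while compound 3 `CNc1nc(NC2CCCC2)nc2ccccc12` reads 39000 nM and so stands highest of the three, beyond the usual scatter from both others.

Compound 4 `CNc1nc(NC)c2ccccc2n1` keeps the methylamino group of compound 3 and changes the other side, with methyl in place of cyclopentyl on a nitrogen on an aromatic ring. Going by the values given here, no two measured compounds differ in just one place, so no direct step can guide the expectation.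

The only hint is loose and rests on three compounds. Compound 2 has larger groups and gives 4600 nM whereas compound 3 has the smallest groups of the three and gives 39000 nM on the same scale. Compound 4 is smaller still, so a higher number is expected. The estimated change is a modest rise a 2.3-fold higher number from compound 3 to compound 4 (0.36 log units; beyond the scatter) and it carries real uncertainty. Compound 4 is estimated at 90000 nM with an expected range of 40000 nM to 250000 nM around that figure.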

Compound 4, half-maximal effective concentration: > 133000 nM
Compound 4: only a limit was reported; the forecaster's own chance of this, stated with the estimate: 35%; at least 1.4-fold (0.16 log units) between middle value and limit.
By their numbers in this assay, from the lowest: compound 2; then compound 1; then compound 3. At a limit, above all of these: compound 4.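

Cyclopentylamino to methylamino is the one change in this series that can be read on its own, and in this assay it gives an at least 3.4-fold higher number from compound 3 to compound 4 (0.53 log units; beyond the scatter). Compound 4 reached only a limit, not a measured number: the limit of > 133000 nM in this assay, at which 1 of the 4 values shown sits. The step therefore fixes the direction and a minimum size, showing that the group on this nitrogen matters in this assay while leaving the full size of the change unknown.

On these data alone, with only cyclopentyl and methyl compared at this place, it remains open whether the number follows the carbon count of the group or depends on the presence of a ring. A pentyl chain, which has the same carbon count as cyclopentyl but no ring, would help separate these two readings, and a cyclohexyl ring would extend the comparison among rings.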